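The source may report more compounds than this note shows. Statements on the series, on what has been measured and on what is new or still open speak of the compounds shown alone.

Three compounds have been measured in a functional assay on MCF7 cells (Homo sapiens) for antiproliferative activity, read by sulforhodamine B assay, with a stated time of 3 days; on this read-out lower numbers stand for stronger inhibition and higher numbers for weaker inhibition:

Compound 1 `c1ccc2c(c1)COC(n1cnc3ncnc(OCC4CCCCC4)c31)CO2`: 13400 nM
Compound 2 `Clc1ccc(Sc2ncnc3ncn(C4COc5ccccc5CO4)c23)c(Cl)c1`: 8400 nM
Compound 3 `c1ccc(Sc2ncnc3ncn(C4COc5ccccc5CO4)c23)cc1`: 15600 nM

Compound 3, at 15600 nM, cannot be separated from the other two. The data show a 1.2-fold higher number from compound 1 to compound 3 (0.07 log units; within the scatter) and a 1.9-fold higher number from compound 2 to compound 3 (0.27 log units; within the scatter), so the three values form a single group with no reliable order.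

The next compound is compound 4 `CSc1ncnc2ncn(C3COc4ccccc4CO3)c12`, which has methyl in place of phenyl on a sulfur. The closest evidence is the other change made on that sulfur, a 1.9-fold higher number from compound 2 to compound 3 (0.27 log units; within the scatter). The swap at the same carbon of the core, a 1.6-fold lower number from compound 1 to compound 2 (0.20 log units; within the scatter), also stayed small, as did a 1.2-fold higher number from compound 1 to compound 3 (0.07 log units; within the scatter). Thus, neither replacing the group on the sulfur nor replacing the whole sulfanyl substituent has moved the number in this assay beyond the scatter. However, no measured compound carries methyl on the sulfur, so this is an extrapolation and the range must stay wide.

No step beyond the scatter is expected, and the estimated change is a 1.2-fold higher number from compound 3 to compound 4 (0.06 log units; within the scatter). For compound 4 the expected value is 18000 nM, with an estimated range of 8000 nM to 45000 nM.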

Compound 4, half-maximal inhibitory concentration: 31800 nM
For compound 4 the middle estimate is 1.8-fold (0.25 log units) below the measured one; measured number inside the range.
By their numbers in this assay, from the lowest: compounds 2, 1 and 3 (each within the scatter of the next); then compound 4.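

In this assay, for the compounds shown here, the group on the sulfur matters after all: methyl gives a 2.0-fold higher number from compound 3 to compound 4 (0.31 log units; beyond the scatter) in place of phenyl and a 3.8-fold higher number from compound 2 to compound 4 (0.58 log units; beyond the scatter) in place of 2,4-dichlorophenyl, the first steps at this position to lie beyond the scatter. The change at the aromatic carbon tells the same story, since methylsulfanyl in place of cyclohexylmethoxy gives a 2.4-fold higher number from compound 1 to compound 4 (0.38 log units; beyond the scatter) while the two arylsulfanyl groups stayed within the scatter of cyclohexylmethoxy, so compound 4 is the weakest of the four and the only one set apart, though all three steps are modest. Nothing shown here accounts for this difference between methyl and the ring-bearing groups.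

From the compounds shown here alone, the separation rests on compound 4 alone, so it remains open whether a longer chain on the sulfur, such as n-butyl, would stay with compound 4 or join the other three. Also open, going by these compounds, is how a benzyl group on the sulfur, or an amine in place of the sulfanyl substituent on the aromatic carbon, would read in this assay as well.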